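Trading the methoxyphenyl arm for a fluorophenyl

The source may report more compounds than this note shows. Statements on the series, on what has been measured and on what is new or still open speak of the compounds shown alone.

Compound 1 `COc1ccc(-n2ncnc2-c2cc(OC)c(OC)c(OC)c2)cc1`: 7400 nM in a functional assay on MCF7 cells (Homo sapiens) for antiproliferative activity, read by MTT assay, with a stated time of 72 h; on this read-out lower numbers stand for stronger inhibition and higher numbers for weaker inhibition
Compound 2 `COc1cc(-c2ncnn2-c2ccc([N+](=O)[O-])cc2)cc(OC)c1OC`: > 10000 nM, a limit of this assay
Compound 3 `COc1cc(-n2ncnc2-c2ccc(SC)cc2)cc(OC)c1OC`: 390 nM

Of the two numbers in this assay, compound 1 has the highest, and compound 3 lies far lower, well beyond the usual scatter. Compound 2 reaches only a limit, (the limit of > 10000 nM in this assay, at which 1 of the 3 values shown sits). Compound 4 `COc1cc(-c2ncnn2-c2cccc(F)c2)cc(OC)c1OC` differs from compound 1 by 3-fluorophenyl in place of 4-methoxyphenyl on an aromatic nitrogen. Among the compounds with values here, the only measured step touching this same ring, an at least 1.3-fold higher number from compound 1 to compound 2 (0.13 log units; that floor lies within the scatter), runs toward weaker inhibition and is small. Within the data shown here, compound 3, with methylthio in place of methoxy there, shows a much lower number, but no single step connects it to compound 4. Compound 4 is therefore expected to stay close to compound 1, a 1.2-fold lower number from compound 1 to compound 4 (0.09 log units; within the scatter), giving an estimated 6000 nM between 1500 nM and 15000 nM.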

Compound 4, half-maximal inhibitory concentration: > 10000 nM
Compound 4 gave a limit, no number; the forecaster's own chance of this, stated with the estimate: 25%; middle value at least 1.6-fold (0.22 log units) away from the limit.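

The change to 3-fluorophenyl in place of 4-methoxyphenyl on the aromatic nitrogen gives an at least 1.3-fold higher number from compound 1 to compound 4 (0.13 log units; that floor lies within the scatter), so only a floor is known for this step. In this assay compound 4 gives > 10000 nM, which is a limit and not a number. Compound 4 now joins compound 2 at that same limit: the limit of > 10000 nM in this assay, at which 2 of the 4 values shown sit.

The compounds shown cannot separate the effect of the fluorine from that of its place on the ring. They also leave open how this arm would fare carrying an amine or an ethylthio chain.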